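From Methoxy to Fluoro on an Aromatic Carbon

The source may report more compounds than this note shows. Statements on the series, on what has been measured and on what is new or still open speak of the compounds shown alone.

Compound 3 `C=C1[C@@H](OC(C)=O)C[C@@H]2[C@](C)(COC=O)[C@H](OC(C)=O)CC[C@@]2(C)[C@@H]1C[C@@H](Nc1ccc(OC)cc1)C1=CCOC1=O` carries the highest number among the three compounds measured in a functional assay on A549 cells (Homo sapiens) for cytotoxicity, read by sulforhodamine B assay; a lower number here means a stronger inhibitor, a higher number a weaker inhibitor: compound 3 gives 28900 nM. Compound 1 `C=C1[C@@H](OC(C)=O)C[C@@H]2[C@](C)(CO[Si](C)(C)C(C)(C)C)[C@H](OC(C)=O)CC[C@@]2(C)[C@@H]1C[C@@H](Nc1ccc(OC)cc1)C1=CCOC1=O` gives 4810 nM, and compound 2 `C=C1CC[C@@H]2[C@](C)(CO[Si](C)(C)C(C)(C)C)[C@H](OC(C)=O)CC[C@@]2(C)[C@@H]1C/C=C1/C(=O)OC[C@H]1OC(C)=O` gives 3990 nM. The one traced change among these, a 6.0-fold higher number from compound 1 to compound 3 (0.78 log units; beyond the scatter), concerns the group on an oxygen on a saturated carbon and says nothing about the aromatic ring.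

Compound 4 `C=C1[C@@H](OC(C)=O)C[C@@H]2[C@](C)(COC=O)[C@H](OC(C)=O)CC[C@@]2(C)[C@@H]1C[C@@H](Nc1ccc(F)cc1)C1=CCOC1=O` differs from compound 3 in a single place: fluoro in place of methoxy on an aromatic carbon. Within the data shown here, no measured pair here alters the group on the aromatic ring, so no step bears directly on this change; the single comparison available sits elsewhere in the molecule and cannot be carried over. With nothing pointing in either direction, the expectation is a step that stays within the scatter, and compound 4 is therefore estimated at 27000 nM, with a range from 9000 nM to 80000 nM, which means the expected step is a 1.1-fold lower number from compound 3 to compound 4 (0.03 log units; within the scatter).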

Compound 4, half-maximal inhibitory concentration: 21300 nM
The estimate for compound 4 lay 1.3-fold (0.10 log units) above the measured number; the measured number falls inside the stated range.
By their numbers in this assay, from the lowest: compounds 2 and 1 (each within the scatter of the next); then compounds 4 and 3 (each within the scatter of the next).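

In this assay, among these compounds, this is the first direct test of the ring position para to a large group, since the earlier step concerned only the group on an oxygen on a saturated carbon. Replacing methoxy with fluoro gives a 1.4-fold lower number from compound 3 to compound 4 (0.13 log units; within the scatter), so the two compounds cannot be told apart, even though the hydrogen-bond acceptor counted on methoxy is absent from fluoro. No measurement shown here offers an explanation for this result.

As far as these compounds go, two groups that read alike do not show that this position is indifferent to every change, and what an amine, a carboxylic acid or a longer chain would do at the same place remains open. From the compounds shown here alone, it is also open whether fluoro and methoxy would still read alike with the larger group on oxygen that compound 1 carries.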